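The compounds below may be only part of what the source reports. "The series", "measured", "known", "first", "only" and "open" are said of these compounds alone.

In a functional assay on SF-268 cells (Homo sapiens) for antiproliferative activity, read by sulforhodamine B assay, with a stated time of 72 h (on this read-out lower numbers stand for stronger inhibition and higher numbers for weaker inhibition), compound 1 (`O=C1CS/C(=N/Nc2nncc3ccccc23)N1c1ccccc1`) gives 7 nM, compound 2 (`Cc1cc(C)nc(NS(=O)(=O)c2ccc(Nc3nncc4ccccc34)cc2)n1`) gives 7.6 nM and compound 3 (`C(=C/c1ccccc1)\C(=N\Nc1nncc2ccccc12)c1ccccc1`) gives 3.2 nM. Compound 2 cannot be told apart from compound 1, while its number is higher than that of compound 3 by a gap beyond the scatter. Compound 4 (`O=S(=O)(Nc1ncccn1)c1ccc(Nc2nncc3ccccc23)cc1`) has pyrimidin-2-yl in place of 4,6-dimethylpyrimidin-2-yl on a sulfonamide nitrogen. For the measured compounds named here, no measured pair shows the effect of such a change, so no step beyond the scatter is expected in this assay, in either direction. The estimated step, a 1.1-fold higher number from compound 2 to compound 4 (0.02 log units; within the scatter), therefore stays small. The expected value for compound 4 is 8 nM, within an estimated range of 2.5 nM to 25 nM.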

Compound 4, half-maximal inhibitory concentration: 34 nM
For compound 4 the middle estimate is 4.3-fold (0.63 log units) below the measured one; measured number above the stated range.
By their numbers in this assay, from the lowest: compound 3; then compounds 1 and 2 (each within the scatter of the next); then compound 4.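

For the compounds shown here, the sulfonamide nitrogen of compound 2 proves to be a place where the substituent counts: in this assay, pyrimidin-2-yl in place of 4,6-dimethylpyrimidin-2-yl gives a 4.5-fold higher number from compound 2 to compound 4 (0.65 log units; beyond the scatter), a change the earlier compounds could not show. The ring type and the counted donors and acceptors stay the same, so the step goes with the loss of the dimethyl substitution alone. Nothing available explains this step.

From the compounds shown here alone, whether thiazol-2-yl, phenyl or acetyl on that nitrogen would track compound 2 or compound 4 remains open. So does whether a single methyl on the pyrimidine ring would recover part of the step.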